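A few compounds are considered here, and "the series" means these few. Any claim that something is new, unique, unknown or untested is made for them only; others in the source may bear on it.

Compound 1, `N=c1c(C(N)=O)cccn1Cc1ccccc1`: in an assay on CHO-K1 cells for displacement of a labelled ligand from Alpha-1D adrenergic receptor (Homo sapiens), read by scintillation counting, with a stated time of 60 min (on this read-out lower numbers stand for stronger inhibition and higher numbers for weaker inhibition), compound 1 gives 880 nM.
Compound 2, `N=c1c(C(N)=O)cc(Cl)cn1Cc1cccc(C(N)=O)c1`: compound 2 gives 26 nM.
Compound 3, `N=c1c(C(N)=O)cc(Cl)cn1Cc1ccc(C(N)=O)c(Cl)c1`: compound 3 gives 65 nM.

Compound 3 holds the middle place among these three: its number lies above that of compound 2 and below that of compound 1, and both gaps exceed the usual scatter of repeated measurements. Compound 4, `N#Cc1ccc(Cn2cc(Cl)cc(C(N)=O)c2=N)cc1Cl`, has not yet been measured. It differs from compound 3 in one place: cyano in place of carbamoyl on an aromatic carbon. Among the compounds with values here, no pair of measured compounds shows how this exchange plays out, so the expectation rests on the change itself. A modest rise in the number, close to the edge of the scatter, is expected. Compound 4 is therefore estimated at 120 nM, with a likely range from 40 nM to 400 nM. The expected step, a 1.8-fold higher number from compound 3 to compound 4 (0.27 log units; within the scatter), is small and toward weaker inhibition.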

Compound 4, inhibition constant: 11 nM
Compound 4: the middle estimate sits 11-fold (1.04 log units) above what was measured; the whole stated range lies above it.
By their numbers in this assay, from the lowest: compound 4; then compound 2; then compound 3; then compound 1.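

On the aromatic carbon ortho to a chloro group and para to a large group, cyano in place of carbamoyl gives a 5.9-fold lower number from compound 3 to compound 4 (0.77 log units; beyond the scatter) in this assay. So, with this chloro group in place, the carbamoyl is not required at this position for a low number, and the cyano, with 0 hydrogen-bond donors, does better here. Nothing shown gives a reason for this drop. Going by these compounds, whether the exchange gives a similar step without the chloro group remains open. So does how an amine or a carboxylic acid at this position would compare.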